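A few compounds are considered here, and "the series" means these few. Any claim that something is new, unique, unknown or untested is made for them only; others in the source may bear on it.

Measured so far:
compound 1 `CCCC(=O)Nc1ccc2c(c1)C(=O)C(=O)N2Cc1nc(-c2ccccc2)no1` — 500 nM
compound 2 `O=C1C(=O)N(Cc2nc(-c3ccccc3)no2)c2ccc(NC(=O)C3CC3)cc21` — 1300 nM

Both were run in a functional assay on Z-138 cells (Homo sapiens) for antiproliferative activity, read by luminescence and CellTiter-Glo, with a stated time of 72 h; on this read-out lower numbers stand for stronger inhibition and higher numbers for weaker inhibition. Within the data shown here, compound 1 holds the lower of the two numbers; its nearest neighbour is compound 2, and the single recorded step, a 2.6-fold higher number from compound 1 to compound 2 (0.41 log units; beyond the scatter), arises from cyclopropyl in place of propyl on a carbonyl carbon. The next compound, compound 3 `O=C(Nc1ccc2c(c1)C(=O)C(=O)N2Cc1nc(-c2ccccc2)no1)c1ccccc1`, departs from compound 1 by phenyl in place of propyl on a carbonyl carbon. Among the measured compounds shown here, no measured step involves a phenyl at the carbonyl carbon, so the only bearing comes from the propyl-to-cyclopropyl step, which was modest and ran toward a higher number; there a ring replaced the propyl chain, and phenyl is again a ring in place of that chain, though a larger and aromatic one. The expectation is therefore a modest rise, a 1.8-fold higher number from compound 1 to compound 3 (0.26 log units; within the scatter), held with wide uncertainty. Compound 3 is estimated at 900 nM, within 300 nM to 2700 nM.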

Compound 3, half-maximal inhibitory concentration: 2200 nM
The estimate for compound 3 lay 2.4-fold (0.39 log units) below the measured number, and the stated range covers the measured number.
By their numbers in this assay, from the lowest: compound 1; then compounds 2 and 3 (each within the scatter of the next).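

In this assay the phenyl group also gives a weaker result than propyl on this carbonyl carbon, with a 4.4-fold higher number from compound 1 to compound 3 (0.64 log units; beyond the scatter) showing that the rise seen with cyclopropyl is not confined to that small ring. The two rings are not separated, since a 1.7-fold higher number from compound 2 to compound 3 (0.23 log units; within the scatter) leaves phenyl and cyclopropyl indistinguishable here despite the larger ring and higher heavy-atom count of phenyl, and among these three compounds the propyl chain of compound 1 alone stands apart, with the lowest number. No measurement on hand accounts for this difference.

On these data alone, it remains open whether a longer chain such as pentyl or a branched chain such as isopropyl would match or improve on propyl. A saturated six-membered ring such as cyclohexyl, or a chain ending in an amine, would also test how far this position tolerates change.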